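Carbamoyl for Cyano: the Step from Compound 2

The source may report more compounds than this note shows. Statements on the series, on what has been measured and on what is new or still open speak of the compounds shown alone.

Among the compounds with values here, compound 2 `N#Cc1cccc(-c2cnc(C(=O)CCc3ccc(-c4ccccc4)cc3)o2)n1` is the weaker of the two compounds measured so far in an assay for inhibition of Fatty-acid amide hydrolase 1 (Rattus norvegicus) (a higher number here means a weaker inhibitor, a lower number a stronger inhibitor), where compound 2 gives 2.9 nM. Within the data shown here, its only neighbour, compound 1 `CS(=O)(=O)c1cnc(C(=O)CCc2ccc(-c3ccccc3)cc2)o1`, gives 1.2 nM in this assay, and the step of a 2.4-fold higher number from compound 1 to compound 2 (0.38 log units; beyond the scatter) lies beyond the scatter. Compound 3 `NC(=O)c1cccc(-c2cnc(C(=O)CCc3ccc(-c4ccccc4)cc3)o2)n1` arises from compound 2 by the change (carbamoyl in place of cyano on an aromatic carbon), carbamoyl in place of cyano on an aromatic carbon, next to the ring nitrogen and meta to a large group. Among the measured compounds shown here, no measured step exchanges one substituent for another on this ring; the single recorded step replaces methylsulfonyl with 6-cyanopyridin-2-yl and does not bear directly on the present change. The account therefore expects at most a small movement for compound 3 in this assay, with no direction settled beyond the scatter, an expected step of a 1.4-fold higher number from compound 2 to compound 3 (0.14 log units; within the scatter). Compound 3 is estimated at 4 nM, within 1.5 nM to 12 nM.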

Compound 3, inhibition constant: 1.2 nM
For compound 3 the middle estimate is 3.3-fold (0.52 log units) above the measured one, outside the stated range (below it).
By their numbers in this assay, from the lowest: compounds 1 and 3 (each within the scatter of the next); then compound 2.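

In this assay, the aromatic carbon next to the ring nitrogen proves sensitive to what it carries: carbamoyl in place of cyano gives a 2.4-fold lower number from compound 2 to compound 3 (0.38 log units; beyond the scatter) and so reverses the loss seen with the nitrile. The 6-carbamoylpyridin-2-yl group also matches methylsulfonyl, with no change at the digits printed from compound 1 to compound 3 (within the scatter), so a pyridine-bearing compound can equal compound 1 in this assay. The exchange adds one hydrogen-bond donor, but nothing on hand explains why the number falls.

Going by these compounds, whether the step goes with that donor stays open, since a single pair cannot separate it from the other differences between the two groups. A carboxylic acid, a methyl ester or a methylamide at this carbon could show whether compound 3 or compound 2 sets the trend.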